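Swapping the terminal phenyl substituent in thromboxane antagonists

This account rests on a few compounds, and the source may have more. Where it says the series, first, only, none or still open, it means among the compounds named here.

Measured compounds:
Compound 1 `CC(=O)NCc1ccccc1-c1ccc(COC2CC[C@H](N3CCCCCC3)[C@H]2OC/C=C\CCC(=O)O)cc1`: in a functional assay for antagonist activity at thromboxane A2 receptor (Rattus norvegicus) (a higher number here means weaker binding, a lower number tighter binding), compound 1 gives 126 nM.
Compound 2 `NC(=O)c1ccccc1-c1ccc(COC2CC[C@H](N3CCCCCC3)[C@H]2OC/C=C\CCC(=O)O)cc1`: in this assay compound 2 gives 15.9 nM.
Compound 3 `CS(=O)(=O)Nc1ccccc1-c1ccc(COC2CC[C@H](N3CCCCCC3)[C@H]2OC/C=C\CCC(=O)O)cc1`: in this assay compound 3 gives 3.98 nM.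

Compound 3 has the lowest number of the three, with a 4.0-fold lower number from compound 2 to compound 3 (0.60 log units; beyond the scatter) and a 32-fold lower number from compound 1 to compound 3 (1.50 log units; beyond the scatter) both beyond the scatter. Compound 4 `O=C(O)CC/C=C\CO[C@H]1C(OCc2ccc(-c3ccc(CO)cc3)cc2)CC[C@@H]1N1CCCCCC1` differs from compound 3 in one place: 4-(hydroxymethyl)phenyl in place of 2-(methanesulfonamido)phenyl on an aromatic carbon. The measured steps all change the group on that same phenyl and each was beyond the scatter, the largest being a 32-fold lower number from compound 1 to compound 3 (1.50 log units; beyond the scatter). Within the data shown here, no step covers a hydroxymethyl group, so the direction rests on the spread seen so far. Since every substituent differing from methanesulfonamido gave a higher number, compound 4 is expected to bind less tightly, estimated at 50 nM (range 10 nM to 250 nM), a step of a 13-fold higher number from compound 3 to compound 4 (1.10 log units; beyond the scatter).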

Compound 4, dissociation constant: 20 nM
Estimate against measurement, compound 4: 2.5-fold (0.40 log units) above; the range from low to high includes it.
By their numbers in this assay, from the lowest: compound 3; then compounds 2 and 4 (each within the scatter of the next); then compound 1.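

Compound 4 is the first one shown whose terminal phenyl group is not 2-substituted and carries no nitrogen, and in this assay this change still gives a 6.3-fold lower number from compound 1 to compound 4 (0.80 log units; beyond the scatter). Its result cannot be separated from the 2-carbamoylphenyl result, with a 1.3-fold higher number from compound 2 to compound 4 (0.10 log units; within the scatter), while 2-(methanesulfonamido)phenyl keeps the lowest number, with a 5.0-fold higher number from compound 3 to compound 4 (0.70 log units; beyond the scatter). No evidence here accounts for these differences. Since group and position change together, the compounds shown leave open how 4-(methanesulfonamido)phenyl or 2-(hydroxymethyl)phenyl would compare. They also leave open how a 4-carboxyphenyl or 4-(aminomethyl)phenyl group would behave.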